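Replacing 4-methoxyphenyl with 3-hydroxyphenyl on the shared core

The source may report more compounds than this note shows. Statements on the series, on what has been measured and on what is new or still open speak of the compounds shown alone.

In a functional assay on HeLa cells (Homo sapiens) for antiproliferative activity, read by MTT assay, with a stated time of 48 h (a lower number here means a stronger inhibitor of growth, a higher number a weaker inhibitor of growth), compound 2 `COC(=O)N1N=C(c2ccc(OC)cc2)CC1c1cc(OC)c(OC)c(OC)c1` gives 2590 nM. Among the measured compounds shown here, the only other measured compound, compound 1 `COC(=O)N1N=C(c2cccc(OC)c2)CC1c1cc(OC)c(OC)c(OC)c1`, gives 1530 nM, and these two values lie within the scatter of each other. Compound 3 `COC(=O)N1N=C(c2cccc(O)c2)CC1c1cc(OC)c(OC)c(OC)c1` keeps the shared core and differs from compound 2 in one group: 3-hydroxyphenyl in place of 4-methoxyphenyl on a carbon with a double bond to nitrogen. Here, 3-hydroxyphenyl takes the place of 4-methoxyphenyl on a carbon with a double bond to nitrogen.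

For the measured compounds named here, one measured step bears on this change. Exchanging 3-methoxyphenyl for 4-methoxyphenyl gave a 1.7-fold higher number from compound 1 to compound 2 (0.23 log units; within the scatter). Going by the values given here, that step shows only a small response to a change in this group, but it involves no hydroxyphenyl compound, so the effect of 3-hydroxyphenyl in this assay remains untested. With so little evidence, no shift beyond the scatter is expected, in either direction, and the range must stay wide. The expected change is a 1.3-fold lower number from compound 2 to compound 3 (0.11 log units; within the scatter). For compound 3, the estimated value is 2000 nM, with an expected range of 650 nM to 6000 nM.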

Compound 3, concentration for 50% growth inhibition: 1970 nM
The estimate for compound 3 lay 1.0-fold (0.01 log units) above the measured number; measured number inside the range.
By their numbers in this assay, from the lowest: compounds 1, 3 and 2 (each within the scatter of the next).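

In this assay, compound 3 is the only compound shown with a hydrogen-bond donor on this aromatic ring, and moving to that group gives a 1.3-fold lower number from compound 2 to compound 3 (0.12 log units; within the scatter) and so does not separate the two compounds. The cleaner comparison removes only the methyl on the oxygen, leaving the group in the same ring position, and it gives a 1.3-fold higher number from compound 1 to compound 3 (0.11 log units; within the scatter) as the result, so adding this donor has no effect here that can be told from assay scatter, and the three compounds cannot be ranked against one another. No supporting measurement is available to explain this result.

Going by these compounds, these three compounds cover only methoxy and hydroxy groups on this ring, so it remains open whether 4-hydroxyphenyl, or a ring carrying an amine, a carboxylic acid or a longer chain such as butoxy, would move the number beyond the scatter. The compounds also all keep the methoxycarbonyl group and the trimethoxyphenyl ring, which leaves open how much those parts contribute and whether a small response at this position would hold with, for example, an acetyl group in place of the methoxycarbonyl group.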